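A few compounds are considered here, and "the series" means these few. Any claim that something is new, unique, unknown or untested is made for them only; others in the source may bear on it.

Of the compounds shown here, three have been measured in an ADME assay on L02 cells (Homo sapiens) for cytotoxicity, read by MTT assay, with a stated time of 24 h; a higher number here means a weaker inhibitor, a lower number a stronger inhibitor: compound 1 `COc1ccc(/C=C2\CN(C)C/C(=C\c3cccnc3)C2=O)c(OC)c1OC` gave 13600 nM, compound 2 `CN1C/C(=C\c2cccnc2)C(=O)/C(=C/c2ccccc2F)C1` gave 15900 nM, and compound 3 `COc1ccc(/C=C2\CN(C)C/C(=C\c3ccncc3)C2=O)c(OC)c1OC` gave 15600 nM.

Compound 1 and compound 3 share a core and differ only by pyridin-4-yl in place of pyridin-3-yl on a double-bonded chain carbon bound to a double-bonded ring carbon; that change produced a 1.1-fold higher number from compound 1 to compound 3 (0.06 log units; within the scatter). Compound 2 rests on a different core, and the difference between the two cores is not broken down here. Compound 2 and compound 3 give numbers within the usual scatter of each other, as do compound 1 and compound 2, so no order among the three can be read from these data.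

Compound 4 `CN1C/C(=C\c2ccncc2)C(=O)/C(=C/c2ccccc2F)C1` has not yet been measured. It differs from compound 2 by pyridin-4-yl in place of pyridin-3-yl on a double-bonded chain carbon bound to a double-bonded ring carbon, the same change as between compound 1 and compound 3; among these compounds the change occurs in two places. Because compound 2 gives 15900 nM and the same change from compound 1 to compound 3 produced a 1.1-fold higher number from compound 1 to compound 3 (0.06 log units; within the scatter), compound 4 is expected to give about 17000 nM, with a likely range from 8000 nM to 36000 nM. This amounts to an expected step of a 1.1-fold higher number from compound 2 to compound 4 (0.03 log units; within the scatter) in this assay, beside the earlier one, and it rests on that single prior instance of the change, a thin basis.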

Compound 4, half-maximal inhibitory concentration: 14900 nM
Compound 4: the middle estimate sits 1.1-fold (0.06 log units) above what was measured; the measured number falls inside the stated range.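

Carried to a second core, the change from pyridin-3-yl to pyridin-4-yl gave a 1.1-fold lower number from compound 2 to compound 4 (0.03 log units; within the scatter) in this assay, so on this core too the step stays within the scatter. Set beside the earlier instance, the two steps do not differ in any way these data can resolve: the same change on two cores in this assay, a 1.1-fold higher number (0.06 log units; within the scatter) from compound 1 to compound 3 and a 1.1-fold lower number (0.03 log units; within the scatter) from compound 2 to compound 4, 1.2-fold (0.09 log units) apart, within the scatter of two such steps. This shows that on these two cores the change leaves the number in this assay without a readable shift, but it gives the change no direction, and two pairs cannot show that the same would hold on any other core or in any other assay.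

The compounds shown carry only pyridin-3-yl and pyridin-4-yl on the double-bonded chain carbon bound to a double-bonded ring carbon. Going by these compounds, whether a pyridin-2-yl group, a plain phenyl ring or a carboxylic acid-bearing ring in that place would move the number in this assay beyond the scatter remains open.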